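The source may hold more compounds than are shown below. What is called first, only, known or untested is meant among the compounds shown, and "the series" means these compounds.

Measured in an ADME assay on CHO cells (Cricetulus griseus) for inhibition, read by MTT assay; on this read-out higher numbers stand for weaker inhibition and lower numbers for stronger inhibition:
- Compound 1, `CCN(CC)Cc1ccc(C)c(Nc2nc3ccccc3n2Cc2ccc(C#N)cc2)c1O`: > 50000 nM
- Compound 2, `CCN(CC)Cc1cc(C)cc(Nc2nc3ccccc3n2Cc2ccc(F)cc2)c1O`: 18700 nM

Compound 1 gives no true number in this assay, only a limit of the assay: > 50000 nM. Compound 2 gives an actual number, 18700 nM. These two compounds differ in more than one place, so no single structural change can be read from their values.

Compound 3, `CCN(CC)Cc1ccc(C)c(Nc2nc3ccccc3n2Cc2ccc(C(F)(F)F)cc2)c1O`, keeps the core of compound 1 and changes one group: trifluoromethyl in place of cyano on an aromatic carbon. In plain words, trifluoromethyl takes the place of cyano on an aromatic carbon, para to a large group.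

For the measured compounds named here, no measured step shows what this swap does in this assay, so the expectation is cautious. A modest move towards lower numbers, meaning stronger inhibition, seems likely, though compound 3 could also reach the limit and give no number. The expectation leans on compound 2, whose 18700 nM shows that a close relative can give a number in this assay. The expected change is an at least 1.6-fold lower number from compound 1 to compound 3 (0.22 log units; that floor lies within the scatter). For compound 3 the estimated value is 30000 nM, with an expected range from 12000 nM to 70000 nM.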

Compound 3, half-maximal inhibitory concentration: 33900 nM
The estimate for compound 3 lay 1.1-fold (0.05 log units) below the measured number; measured number inside the range.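

In this assay, for the compounds shown here, the change at this place on the benzyl group can now be followed for the first time: with trifluoromethyl in place of cyano on the core of compound 1, the read-out shows an at least 1.4-fold lower number from compound 1 to compound 3 (0.16 log units; that floor lies within the scatter). Compound 1 gives > 50000 nM, which is a limit of the assay and not a number. Only a floor can therefore be stated for this step, and the true shift could be small or considerably larger, because one end of the comparison rests on a limit: the limit of > 50000 nM in this assay, at which 1 of the 3 values shown sits.

The compounds shown leave open how other groups on this aromatic carbon, such as an amine, a carboxylic acid or a longer chain, would read on the same core, and whether any of them would give a number well clear of the limit. Compound 2 differs from compound 3 in more than one place, so the pair cannot separate the effect of the group on the benzyl ring from that of the other structural difference.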